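The source may hold more compounds than are shown below. What is called first, only, known or untested is meant among the compounds shown, and "the series" means these compounds.

Measured so far in a functional assay on A-431 cells (Homo sapiens) for cytotoxicity, read by MTT assay, with a stated time of 48 h; a lower number here means a stronger inhibitor, a higher number a weaker inhibitor:
compound 1 `C/C=C/C=C/C(=O)N[C@H](C(=O)NCCCCCCCC)[C@@H](C)O` gives 58200 nM;
compound 2 `CCCCCCCCCCCCCCCCCCNC(=O)[C@@H](NC(=O)c1nccc2ccccc12)[C@@H](C)O` gives 44100 nM;
compound 3 `CCCCCCCCCCCCCCCCCCNC(=O)[C@@H](NC(=O)/C=C/c1ccccc1)[C@@H](C)O` gives 177000 nM.

Compound 3 stands at the highest number of the three, beyond the scatter from both compound 1 and compound 2. Among the compounds with values here, the one single-point step on record, a 4.0-fold higher number from compound 2 to compound 3 (0.60 log units; beyond the scatter), concerns the acyl group on the amide nitrogen of the shared core and shows that exchanging this group shifts the number by a modest but real amount.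

Compound 4 `C/C=C/C=C/C(=O)N[C@H](C(=O)NCCCCCCCCCCCCCCCCCC)[C@@H](C)O` is the next step from compound 3: prop-1-en-1-yl in place of phenyl on a double-bonded chain carbon bound to a double-bonded chain carbon; cut one bond further out, 2-phenylethenyl becomes penta-1,3-dien-1-yl. Compound 4 thus carries the acyl group of compound 1 on the amide chain of compound 3. Within the data shown here, no single-point step between compound 1 and compound 3 exists, since they differ in two places; their two values simply show compound 1 at the lower number. Among the measured compounds shown here, the step of a 4.0-fold higher number from compound 2 to compound 3 (0.60 log units; beyond the scatter) is the only measured guide and sets the likely size of an acyl exchange. The step of a 3.0-fold lower number from compound 3 to compound 4 (0.47 log units; beyond the scatter) is therefore expected to be a modest fall, toward the region of compound 1 and compound 2. Compound 4 is estimated at 60000 nM in this assay, with a range from 20000 nM to 180000 nM.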

Compound 4, half-maximal inhibitory concentration: 187000 nM
Estimate against measurement, compound 4: 3.1-fold (0.49 log units) below; measured number above the stated range.
By their numbers in this assay, from the lowest: compounds 2 and 1 (each within the scatter of the next); then compounds 3 and 4 (each within the scatter of the next).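

In this assay, the step with prop-1-en-1-yl in place of phenyl is a 1.1-fold higher number from compound 3 to compound 4 (0.02 log units; within the scatter), so this position does not separate the 2-phenylethenyl and penta-1,3-dien-1-yl acyl groups, and the ring of the cinnamoyl-type group leaves no mark on the number. Isoquinolin-1-yl on the carbonyl carbon now stands apart from both of these groups, with the step to the dienyl acyl group being a 4.2-fold higher number from compound 2 to compound 4 (0.63 log units; beyond the scatter), which adds a second comparison to the one with 2-phenylethenyl. Within the data shown here, the amide chain can also be read on its own for the first time: decyl in place of hydrogen on a saturated chain carbon, eight bonds along the chain from an amide-type nitrogen, gives a 3.2-fold higher number from compound 1 to compound 4 (0.51 log units; beyond the scatter), a real change from a single pair with the penta-1,3-dien-1-yl acyl group held fixed.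

Nothing at hand accounts for any of these steps. Still open, from the compounds shown here alone, are whether the chain step holds with the isoquinolin-1-yl acyl group, and whether an amine or a carboxylic acid on the acyl group or at the end of the chain would move the number beyond the scatter.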